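Trifluoromethyl for bromo on the benzyl arm of compound 3

The source may report more compounds than this note shows. Statements on the series, on what has been measured and on what is new or still open speak of the compounds shown alone.

Measured compounds:
compound 1 `CC1(C)OB(c2ccc(COc3ccc(CNC(=O)[C@H]4CCC(=O)N4Cc4ccccc4)cc3)cc2)OC1(C)C` gives 180 nM in an assay on HEK293 cells for inhibition of Ataxin-2 (Mus musculus), read by fluorescence and Amplex Red; a lower number here means a stronger inhibitor, a higher number a weaker inhibitor
compound 2 `O=C(O)c1ccc(COc2ccc(CNC(=O)[C@@H]3CCC(=O)N3Cc3ccccc3)cc2)cc1` gives 4500 nM in this assay
compound 3 `O=C(O)c1ccc(COc2ccc(CNC(=O)[C@@H]3CCC(=O)N3Cc3ccc(Br)cc3)cc2)cc1` gives > 5000 nM in this assay

In this assay compound 3 reports only a limit, > 5000 nM, and not a number. Among the compounds with values here, compound 2 stands at 4500 nM, and the one measured step on this part of the molecule, an at least 1.1-fold higher number from compound 2 to compound 3 (0.04 log units; that floor lies within the scatter), lies within the scatter. Compound 1, with its boronate ester in place of the carboxylic acid, stands at 180 nM.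

Compound 4 `O=C(O)c1ccc(COc2ccc(CNC(=O)[C@@H]3CCC(=O)N3Cc3ccc(C(F)(F)F)cc3)cc2)cc1` differs from compound 3 by trifluoromethyl in place of bromo on an aromatic carbon. Within the data shown here, no measured step exchanges one such group for another, so the only bearing comes from the step from compound 2 to compound 3, which was small. Because compound 3 sits at the limit of > 5000 nM in this assay, at which 1 of the 3 values shown sits, compound 4 is also expected to give a limit rather than a number, and the expected step that the limit leaves unreadable from compound 3 to compound 4 is none beyond the scatter. Compound 4 is therefore estimated at 7000 nM, with a range from 2500 nM to 20000 nM.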

Compound 4, half-maximal inhibitory concentration: > 5000 nM
Compound 4: a limit, no number (the forecaster's own chance of this, stated with the estimate: 65%); the middle value lies beyond the limit too.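

In this assay compound 4 gives > 5000 nM, which is a limit of the assay and not a number. Trifluoromethyl in place of hydrogen on the benzyl arm gives an at least 1.1-fold higher number from compound 2 to compound 4 (0.04 log units; that floor lies within the scatter), so this second group at the position, like bromo before it, yields no number for comparison with the unsubstituted benzyl of compound 2. The step between compound 3 and compound 4 cannot be read, and the exchange of bromo for trifluoromethyl therefore shows only that both compounds end at the same limit: the limit of > 5000 nM in this assay, at which 2 of the 4 values shown sit.

As far as these compounds go, how far beyond that limit compound 3 and compound 4 lie remains open. So does whether an amine or a methoxy group at this position, or trifluoromethyl paired with the boronate ester in place of the carboxylic acid, would give a readable number.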